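This account rests on a few compounds, and the source may have more. Where it says the series, first, only, none or still open, it means among the compounds named here.

Within the data shown here, compound 2, `CN(C)CCn1cnnc1-c1cc(Oc2ccc(NC(=O)N/N=C/c3ccc(F)cc3Cl)cc2F)ccn1`, gives 870 nM in a functional assay on MKN-45 cells (Homo sapiens) for cytotoxicity, read by MTT assay, with a stated time of 72 h (a higher number here means a weaker inhibitor, a lower number a stronger inhibitor), and carries the lowest of the three numbers measured so far. Compound 1, `CN(C)CCn1cnnc1-c1cc(Oc2ccc(NC(=O)N/N=C/c3cccc(O)c3)cc2F)ccn1`, gives 1370 nM, and the step of a 1.6-fold lower number from compound 1 to compound 2 (0.20 log units; within the scatter) leaves the two indistinguishable. Compound 3, `CN(C)CCn1cnnc1-c1cc(Oc2ccc(NC(=O)N/N=C/c3ccc(O)c(O)c3)cc2F)ccn1`, gives 3240 nM; the steps of a 3.7-fold higher number from compound 2 to compound 3 (0.57 log units; beyond the scatter) and a 2.4-fold higher number from compound 1 to compound 3 (0.37 log units; beyond the scatter) are the only ones beyond the scatter in this assay.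

Compound 4, `COc1ccc(/C=N/NC(=O)Nc2ccc(Oc3ccnc(-c4nncn4CCN(C)C)c3)c(F)c2)c(OC)c1`, differs from compound 2 in one place: 2,4-dimethoxyphenyl in place of 2-chloro-4-fluorophenyl on a carbon with a double bond to nitrogen. The bearing steps are those that swap the aryl group on the same carbon. Going from the chloro-fluoro ring to a hydroxylated ring gave a 1.6-fold lower number from compound 1 to compound 2 (0.20 log units; within the scatter) reversed, within the scatter, and a 3.7-fold higher number from compound 2 to compound 3 (0.57 log units; beyond the scatter), a modest rise. The dimethoxy ring brings acceptors but no donors, so a step toward compound 3 is plausible but not assured. A modest rise or no change beyond the scatter is expected, a 1.7-fold higher number from compound 2 to compound 4 (0.24 log units; within the scatter). Compound 4 is estimated at 1500 nM in this assay, within 700 nM to 3500 nM.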

Compound 4, half-maximal inhibitory concentration: 1680 nM
Compound 4: the middle estimate sits 1.1-fold (0.05 log units) below what was measured; the range from low to high includes it.
By their numbers in this assay, from the lowest: compounds 2, 1, 4 and 3 (each within the scatter of the next, the first and the last beyond it).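

In this assay, 2,4-dimethoxyphenyl on the carbon with a double bond to nitrogen stays within the scatter of all three earlier aryl groups (a 1.9-fold higher number from compound 2 to compound 4 (0.29 log units; within the scatter); a 1.2-fold higher number from compound 1 to compound 4 (0.09 log units; within the scatter); a 1.9-fold lower number from compound 3 to compound 4 (0.29 log units; within the scatter)). Compound 4 thus falls inside the one gap of the series that lies beyond the scatter (a 3.7-fold higher number from compound 2 to compound 3 (0.57 log units; beyond the scatter)), and the two hydrogen-bond acceptors of the entering group, against none in 2-chloro-4-fluorophenyl, bring no step beyond the scatter from either end. Nothing measured on these compounds accounts for this result.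

Open, on these data alone, is whether an aryl group carrying an amine or a carboxylic acid at this place would move the number beyond the scatter of compound 2. Also open, as far as these compounds go, is whether a single methoxy group would behave as the pair does in compound 4.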